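The source may report more compounds than this note shows. Statements on the series, on what has been measured and on what is new or still open speak of the compounds shown alone.

In an in vitro functional assay on Sf9 cells for antagonist activity at histamine H2 receptor (Homo sapiens) (on this read-out lower numbers stand for lower potency and higher numbers for higher potency (the scale is a negative logarithm)), compound 3, `N#C/N=C(\NCCCCc1ccccc1)NCCCCc1c[nH]cn1`, stands at 5.03, the lower of the two plain numbers recorded here, with compound 2, `N#C/N=C(/NCCCCc1c[nH]cn1)NCCCc1ccccc1`, nearest at 5.25. The step of a number 0.22 log units lower from compound 2 to compound 3 (within the scatter) lies within the scatter, so the two are not distinguished by this assay. Compound 1, `N#C/N=C(/NCCCc1c[nH]cn1)NCCCC1CCCCC1`, is reported in this assay only as a limit, < 5; < 5 (2 entries), not as a number. Compound 4, `N#C/N=C(/NCCCCc1c[nH]cn1)NCCCC1CCCCC1`, differs from compound 3 by cyclohexyl in place of benzyl on a saturated chain carbon, three bonds along the chain from an amine nitrogen. Within the data shown here, no measured step covers this particular exchange: the only measured step, from compound 2 to compound 3, concerns chain length and was within the scatter, and compound 1, which carries the same cyclohexylpropyl chain as compound 4, shows only a limit. Because compound 1 gives < 5; < 5 (2 entries), compound 4 is expected to fall somewhat, with a step of about a number 0.23 log units lower from compound 3 to compound 4 (within the scatter). Compound 4 is therefore estimated at 4.8, within 4.3 to 5.3.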

Compound 4, negative logarithm of the antagonist equilibrium constant: < 5
Compound 4 was reported as a limit; the forecaster's own chance of this, stated with the estimate: 55%; the middle value is on the limit's open side.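

In this assay compound 4 is reported only as a limit, < 5, not as a number. At this place, on a saturated chain carbon, three bonds along the chain from an amine nitrogen, cyclohexyl gives a number at least 0.03 log units lower from compound 3 to compound 4 (that floor lies within the scatter), and in place of phenyl it gives a number at least 0.25 log units lower from compound 2 to compound 4 (that floor lies within the scatter), so neither exchange shows any gain in potency. Compound 1 and compound 4, the two cyclohexyl compounds shown, are both reported as limits, while the phenyl-ended compound 2 and compound 3 carry plain numbers, and the size of each new step ends at that limit: the limit of < 5 in this assay, at which 1 of the 4 values shown sits.

The compounds shown leave open how far compound 4 really lies past the limit, and so whether either step exceeds the scatter. They also leave open whether an amine or a hydroxyl on the cyclohexyl ring, or a longer chain carrying that ring, would return a plain number.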